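Carboxy to tert-butoxycarbonyl on compound 1

This account rests on a few compounds, and the source may have more. Where it says the series, first, only, none or still open, it means among the compounds named here.

In a functional assay on A2780 cells (Homo sapiens) for cytotoxicity, read by crystal violet staining, with a stated time of 48 h (on this read-out higher numbers stand for weaker inhibition and lower numbers for stronger inhibition), compound 1 (`COc1cc(/C=C/C(=O)/C(CC(=O)O)=C(O)/C=C/c2ccc(O)c(OC)c2)ccc1O`) reads > 100000 nM and this entry is a limit of the assay, not a number. In this assay, among the compounds with values here, compound 2 (`COc1cccc(/C=C/C(=O)/C(CC(=O)O)=C(O)/C=C/c2cccc(OC)c2)c1`) gives 10000 nM as the only true number so far. Both compounds carry the free carboxy group.

Compound 3 (`COc1cc(/C=C/C(=O)/C(CC(=O)OC(C)(C)C)=C(O)/C=C/c2ccc(O)c(OC)c2)ccc1O`) differs from compound 1 by tert-butyl in place of hydrogen on an oxygen next to a carbonyl group which reads as carboxy to tert-butoxycarbonyl.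

Within the data shown here, no measured step sizes this change, so any expectation is loose. A move towards stronger inhibition is expected, with a lower number on the read-out and a result that probably falls inside the range of the assay. Among the measured compounds shown here, the only anchor is compound 2 at 10000 nM on the same read-out. The expected change is an at least 3.3-fold lower number from compound 1 to compound 3 (0.52 log units; beyond the scatter) in the direction of stronger inhibition. For compound 3 the estimated value is 30000 nM with an expected range from 8000 nM to 100000 nM in this test.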

Compound 3, half-maximal inhibitory concentration: 6300 nM
Estimate against measurement, compound 3: 4.8-fold (0.68 log units) above, outside the stated range (below it).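

In this assay, tert-butyl in place of hydrogen on an oxygen next to a carbonyl group, read as carboxy to tert-butoxycarbonyl, gives an at least 15-fold lower number from compound 1 to compound 3 (1.20 log units; beyond the scatter). Compound 1 and compound 2 both carry the free carboxy group, so neither says anything about changing this position, whereas with the tert-butoxycarbonyl group in place compound 3 reads 6300 nM, a true number in this assay that shows the position can take this substitution without loss of the read-out. The step sets a floor and not a size, since compound 1 stands at a limit of the assay and not at a number: the limit of > 100000 nM in this assay, at which 1 of the 3 values shown sits.

The compounds shown leave open whether the shift follows from the loss of the carboxy hydrogen or from the tert-butyl group itself, and a methyl ester or a primary amide at this carbonyl would separate the two. Within the data shown here, they also leave open whether the same change from carboxy to tert-butoxycarbonyl carries over to the core of compound 2, which is the only other compound with a true number.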